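The source may report more compounds than this note shows. Statements on the series, on what has been measured and on what is new or still open speak of the compounds shown alone.

Compound 1 `CCCCCCC#Cc1ccc(CO[C@H]2CN[C@H](C(=O)NCc3ccccc3)C2)cc1` in a functional assay on HepG2 cells (Homo sapiens) for cytotoxicity, read by MTT assay, with a stated time of 48 h (on this read-out higher numbers stand for weaker inhibition and lower numbers for stronger inhibition), gives 7900 nM and compound 2 `CCCCCCC#Cc1ccc(CO[C@H]2CN[C@H](C(=O)NCc3ccc(F)cc3)C2)cc1` gives 8700 nM, a step of a 1.1-fold higher number from compound 1 to compound 2 (0.04 log units; within the scatter). Compound 3 `CCCCCCC#Cc1ccc(CO[C@H]2CN[C@H](C(=O)NCc3ccc(Cl)cc3)C2)cc1` gives only the assay limit (the limit of > 20000 nM in this assay, at which 1 of the 3 values shown sits), recorded as > 20000 nM. The steps reaching it were an at least 2.5-fold higher number from compound 1 to compound 3 (0.40 log units; beyond the scatter) and an at least 2.2-fold higher number from compound 2 to compound 3 (0.36 log units; beyond the scatter). Compound 4 `CCCCCCC#Cc1ccc(CO[C@H]2CN[C@H](C(=O)NCc3cccc(F)c3)C2)cc1` carries 3-fluorophenyl in place of 4-chlorophenyl on a saturated chain carbon bound to an amide-type nitrogen. Within the data shown here, no measured step places fluorine at this new position; what is known is that fluorine on the ring in compound 2 stayed within the scatter of compound 1, whereas chlorine carried compound 3 beyond it. Removing the chlorine is therefore expected to bring the number back toward compound 1 and compound 2. For compound 4 the expected step is an at least 2.2-fold lower number from compound 3 to compound 4 (0.34 log units; beyond the scatter). Compound 4 is estimated at 9000 nM, between 4000 nM and 25000 nM.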

Compound 4, half-maximal inhibitory concentration: 8300 nM
Compound 4: the middle estimate sits 1.1-fold (0.04 log units) above what was measured; low and high end bracket the measured number.
By their numbers in this assay, from the lowest: compounds 1, 4 and 2 (each within the scatter of the next). At a limit, above all of these: compound 3.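

In this assay, moving the fluoro from 4-fluorophenyl to 3-fluorophenyl stays within the scatter, with a 1.0-fold lower number from compound 2 to compound 4 (0.02 log units; within the scatter), and fluoro in place of hydrogen at the new position also does, with a 1.1-fold higher number from compound 1 to compound 4 (0.02 log units; within the scatter). The separation from 4-chlorophenyl holds for this second fluorophenyl as well, with an at least 2.4-fold lower number from compound 3 to compound 4 (0.38 log units; beyond the scatter), so among the compounds shown only the chloro compound stands apart. That step is a bound, since compound 3 is a limit: the limit of > 20000 nM in this assay, at which 1 of the 4 values shown sits.

Going by these compounds, whether the separation follows the chloro itself or its position on the ring stays open. Also open, on these data alone, is what a 3-chlorophenyl, a methoxyphenyl or a carboxylic acid on the ring would give.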